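A few compounds are considered here, and "the series" means these few. Any claim that something is new, unique, unknown or untested is made for them only; others in the source may bear on it.

In a functional assay on SGC-7901 cells (Homo sapiens) for inhibition, read by MTT assay, with a stated time of 24 h (a higher number here means a weaker inhibitor, a lower number a stronger inhibitor), compound 1 (`CC1(C)[C@H]2CC[C@]1(C)N(Cc1cn(-c3ccc(C#N)cc3)nn1)C(=O)C2`) gives 500 nM and compound 2 (`COc1ccccc1-n1cc(CN2C(=O)C[C@@H]3CC[C@@]2(C)C3(C)C)nn1`) gives 280 nM and compound 3 (`CC1(C)[C@H]2CC[C@]1(C)N(Cc1cn(-c3ccccc3O)nn1)C(=O)C2`) gives 410 nM with all three lying within the scatter of one another. Compound 4 (`CC1(C)[C@H]2CC[C@]1(C)N(Cc1cn(-c3ccc(Cl)cc3)nn1)C(=O)C2`) has 4-chlorophenyl in place of 2-hydroxyphenyl on an aromatic nitrogen. Within the data shown here, the measured changes on that aromatic nitrogen (a 1.2-fold lower number from compound 1 to compound 3 (0.09 log units; within the scatter)) and (a 1.8-fold lower number from compound 1 to compound 2 (0.25 log units; within the scatter)) both lie within the scatter, and on that evidence no step beyond the scatter is expected in this assay although no measured compound carries 4-chlorophenyl. The estimated change (a 1.0-fold lower number from compound 3 to compound 4 (0.01 log units; within the scatter)) stays within the scatter. Compound 4 is estimated at 400 nM as the expected value (expected range 180 nM to 900 nM).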

Compound 4, half-maximal inhibitory concentration: 410 nM
Estimate against measurement, compound 4: 1.0-fold (0.01 log units) below, within the range that was stated.
By their numbers in this assay, from the lowest: compounds 2, 3, 4 and 1 (each within the scatter of the next).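

In this assay the series shows no change at the digits printed from compound 3 to compound 4 (within the scatter) and a 1.5-fold higher number from compound 2 to compound 4 (0.17 log units; within the scatter) and a 1.2-fold lower number from compound 1 to compound 4 (0.09 log units; within the scatter) with 4-chlorophenyl on the aromatic nitrogen. Loss of the hydrogen-bond donor and acceptor counted for 2-hydroxyphenyl, and chloro in place of cyano, thus give no step beyond the scatter at this position. Nothing available explains this result. Going by these compounds, whether a carboxylic acid or an amine on the aromatic ring, or a longer alkyl chain in place of the aromatic ring, would give a step beyond the scatter stays open.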